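The compounds below may be only part of what the source reports. "The series", "measured", "known", "first", "only" and "open" are said of these compounds alone.

Measured so far:
Compound 1 `CNC(=O)c1cccc(Cn2nc(C)c(NC(=O)c3ccc(COc4ccccc4OC)cc3)c2C)c1`, in a functional assay on MIA PaCa-2 cells (Homo sapiens) for antiproliferative activity, read by MTT assay, with a stated time of 72 h (on this read-out higher numbers stand for an effect only at larger amounts of compound and lower numbers for an effect already at smaller amounts), compound 1 gives 8500 nM.
Compound 2 `CNC(=O)c1cccc(Cn2nc(C)c(NC(=O)c3ccc(COc4cccc(C(F)(F)F)c4)cc3)c2C)c1`, in this assay compound 2 gives 2300 nM.

Of these two numbers, compound 2 has the lower one, so it acts at smaller amounts than compound 1. Within the data shown here, the one step measured between them is a 3.7-fold lower number from compound 1 to compound 2 (0.57 log units; beyond the scatter), and it shows that exchanging the ring hung on the oxygen on a saturated carbon can shift the number by a modest amount.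

Compound 3 `CNC(=O)c1cccc(Cn2nc(C)c(NC(=O)c3ccc(COc4ccc(C(F)(F)F)cc4C)cc3)c2C)c1` is not yet measured. It differs from compound 2 in that same place: 2-methyl-4-(trifluoromethyl)phenyl in place of 3-(trifluoromethyl)phenyl on an oxygen on a saturated carbon. Among the measured compounds shown here, the only step that bears on this is a 3.7-fold lower number from compound 1 to compound 2 (0.57 log units; beyond the scatter), and it concerns a different pair of rings, so it gives a scale but no direction. The expected step is therefore a 1.1-fold higher number from compound 2 to compound 3 (0.04 log units; within the scatter), with either direction possible. For compound 3 the estimate in this assay is 2500 nM, expected to fall between 800 nM and 8000 nM.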

Compound 3, half-maximal effective concentration: 620 nM
Compound 3: the middle estimate sits 4.0-fold (0.61 log units) above what was measured; measured number outside the range, below it.
By their numbers in this assay, from the lowest: compound 3; then compound 2; then compound 1.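

In this assay a second exchange on the oxygen on a saturated carbon gives a 3.7-fold lower number from compound 2 to compound 3 (0.57 log units; beyond the scatter) and so adds to the first gain: this position can still lower the number once a trifluoromethyl ring is in place. Taken together, the ring exchanges at this one place amount to a 14-fold lower number from compound 1 to compound 3 (1.14 log units; beyond the scatter) while the rest of the molecule stays the same, which makes this a large change and not a modest one. Nothing measured here gives a reason for this shift.

On these data alone, the 2-methyl group and the trifluoromethyl group in its new ring position arrive together in compound 3, so their separate shares remain open. Also open, as far as these compounds go, is how the number would respond to an amine or a carboxylic acid on this ring, or to a longer chain in place of the ring.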